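This account rests on a few compounds, and the source may have more. Where it says the series, first, only, none or still open, it means among the compounds named here.

Of the compounds shown here, three built on one shared core have been tested in an assay on HL-60 cells for agonist activity at vitamin D3 receptor (Homo sapiens), read by microscopy, with a stated time of 96 h; a higher number here means that more compound is needed for the effect, a lower number that less compound is needed. Compound 1 `CC[C@@H](C)[C@H](NC(=O)c1ccc(C(CC)(CC)c2ccc(OCC(O)C(C)(C)C)c(C)c2)n1CC)C(=O)OC` gives 26 nM in this assay. Compound 2 `C#CCNC(=O)c1ccc(C(CC)(CC)c2ccc(OCC(O)C(C)(C)C)c(C)c2)n1CC` gives 240 nM in this assay. Compound 3 `CC[C@@H](C)[C@H](NC(=O)c1ccc(C(CC)(CC)c2ccc(OCC(O)C(C)(C)C)c(C)c2)n1CC)C(=O)O` gives 2.3 nM in this assay, the lowest of the three numbers; its steps to both other compounds lie beyond the scatter, so among these three it is the most potent.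

Compound 4 `CCn1c(C(=O)Oc2ccc(CCO)cc2)ccc1C(CC)(CC)c1ccc(OCC(O)C(C)(C)C)c(C)c1` has not yet been measured. It differs from compound 3 in that (a group of 10 heavy atoms (8 carbon, 2 oxygen; one six-membered aromatic ring of carbon only) in place of a group of 9 heavy atoms (6 carbon, 1 nitrogen, 2 oxygen; no ring), on a carbonyl carbon). The carboxylic acid and the amide of compound 3 are therefore both gone.

Among the measured compounds shown here, two measured steps bear on this. In an 11-fold lower number from compound 1 to compound 3 (1.05 log units; beyond the scatter) the carboxylic acid takes the place of its methyl ester, and in a 100-fold lower number from compound 2 to compound 3 (2.02 log units; beyond the scatter) the whole acid-bearing side chain takes the place of propargyl. Both point the same way: the lowest number belongs to the compound carrying the carboxylic acid. For the measured compounds named here, compound 4 removes it entirely and brings in a group with no counterpart among the measured compounds, so the step is expected to be a clear rise, with wide uncertainty. The step from compound 3 to compound 4 in this assay is estimated as a 65-fold higher number from compound 3 to compound 4 (1.81 log units; beyond the scatter). For compound 4 the expected value in this assay is 150 nM, within a range from 30 nM to 800 nM.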

Compound 4, half-maximal effective concentration: 5100 nM
Compound 4: the middle estimate sits 34-fold (1.53 log units) below what was measured, outside the stated range (above it).
By their numbers in this assay, from the lowest: compound 3; then compound 1; then compound 2; then compound 4.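

In this assay, putting the group with a six-membered aromatic ring of carbon only on the carbonyl carbon gives a 2200-fold higher number from compound 3 to compound 4 (3.35 log units; beyond the scatter). Compounds 1 and 2 also lack that acid, yet the same replacement still gives a 200-fold higher number from compound 1 to compound 4 (2.29 log units; beyond the scatter) and a 21-fold higher number from compound 2 to compound 4 (1.33 log units; beyond the scatter), so this position responds to more than the presence or absence of the acid, and all three compounds that keep the amide nitrogen have lower numbers than compound 4. Nothing measured here explains why the new group fares so badly.

In this one change the amide nitrogen leaves and the aromatic ring enters together, so the compounds shown cannot say which of the two matters more. An amide nitrogen carrying the same ring with its 2-hydroxyethyl chain, a plain methoxy on the carbonyl carbon, or a carboxylic acid placed on the aromatic ring would help to pull these effects apart.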